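Two methoxy groups give way to a single nitro group

The source may report more compounds than this note shows. Statements on the series, on what has been measured and on what is new or still open speak of the compounds shown alone.

Compound 1 `COc1ccc(-c2cc(-c3cc(C(C)C)c(O)cc3C)[nH]c(=O)c2C#N)c(OC)c1` was tested in a functional assay for inhibition, tested at 60 ug/mL (a lower number here means a weaker effect, a higher number a stronger effect of the compound at the concentration tested), where compound 1 gives 48.5%. Among the three measured compounds it stands second highest: compound 2 `COc1ccc(-c2cc(-c3cc(C(C)C)c(O)cc3C)[nH]c(=O)c2C#N)cc1` gives 43%, with a number 5.5 percentage points lower from compound 1 to compound 2 (within the scatter), and compound 3 `Cc1cc(O)c(C(C)C)cc1-c1cc(-c2ccco2)c(C#N)c(=O)[nH]1` gives 55.2%, with a number 6.7 percentage points higher from compound 1 to compound 3 (within the scatter). Compound 4 `Cc1cc(O)c(C(C)C)cc1-c1cc(-c2ccccc2[N+](=O)[O-])c(C#N)c(=O)[nH]1` is not yet measured and differs from compound 1 in one place: 2-nitrophenyl in place of 2,4-dimethoxyphenyl on an aromatic carbon. Within the data shown here, the steps that bear on this exchange are those that swapped the group at the same place, a number 6.7 percentage points higher from compound 1 to compound 3 (within the scatter) and a number 12.2 percentage points higher from compound 2 to compound 3 (beyond the scatter), one within the scatter and one modestly beyond it. A step of no more than that size, without a clear direction, is therefore expected, so compound 4 is estimated at 50%, between 36% and 64%, which means an expected a number 1.5 percentage points higher from compound 1 to compound 4 (within the scatter).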

Compound 4, a percentage reported as inhibition, at one concentration (the size of the read-out at that concentration, not a potency): 31%
For compound 4 the middle estimate is 19 percentage points above the measured one, outside the stated range (below it).
By their numbers in this assay, from the lowest: compound 4; then compounds 2, 1 and 3 (each within the scatter of the next, the first and the last beyond it).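

The position is not indifferent to the group it carries: with 2-nitrophenyl, compound 4 sits clearly below all three earlier compounds (a number 17.5 percentage points lower from compound 1 to compound 4 (beyond the scatter)), (a number 12 percentage points lower from compound 2 to compound 4 (beyond the scatter)) and (a number 24.2 percentage points lower from compound 3 to compound 4 (beyond the scatter)). A change of ring here can therefore lower the number as well as raise it, and the only nitro-bearing compound shown is the weakest of the four at the concentration tested. Nothing measured here accounts for this drop.

Going by these compounds, whether it follows from the nitro group itself or from its place on the phenyl ring remains open. Plain phenyl, 4-nitrophenyl and 2-aminophenyl groups at this position would help separate those two readings.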